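Swapping Dimethylamino for Cyclopentyl on a Shared Core

The compounds below may be only part of what the source reports. "The series", "measured", "known", "first", "only" and "open" are said of these compounds alone.

Compounds measured so far in an assay on isolated protein for inhibition of activin receptor type-2A (Homo sapiens), read by 33P incorporation, with a stated time of 20 min, in the presence of a further agent that is not named here; on this read-out higher numbers stand for weaker inhibition and lower numbers for stronger inhibition:
- compound 1, `COc1cc(-c2cnn3cc(OC)c(-c4cnn(C)c4)nc23)ccn1`, gives 530 nM
- compound 2, `COc1cc(-c2cnn3cc(OC)c(-c4cc(C)no4)nc23)ccn1`, gives 3000 nM
- compound 3, `COc1cc(-c2cnn3cc(OC)c(N(C)C)nc23)ccn1`, gives 3000 nM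

Compound 3 sits, together with compound 2, at the highest number of the three: no change at the digits printed from compound 2 to compound 3 (within the scatter). Compound 1 is the furthest away, with a 5.7-fold higher number from compound 1 to compound 3 (0.75 log units; beyond the scatter). Compound 4, `COc1cc(-c2cnn3cc(OC)c(C4CCCC4)nc23)ccn1`, is the next, unmeasured member; it differs from compound 3 by cyclopentyl in place of dimethylamino on an aromatic carbon. Both measured steps that touch this position compare dimethylamino with an aromatic ring: one gave a modest change, the other none beyond the scatter. Neither involves a saturated carbon ring, so the direction is open. Given compound 3 at 3000 nM, compound 4 is expected near the same level, with no change at the digits printed from compound 3 to compound 4 (within the scatter) as the central guess. The estimate for compound 4 is 3000 nM, expected to lie between 900 nM and 10000 nM.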

Compound 4, half-maximal inhibitory concentration: 2900 nM
For compound 4 the middle estimate is 1.0-fold (0.01 log units) above the measured one; low and high end bracket the measured number.
By their numbers in this assay, from the lowest: compound 1; then compounds 4, 2 and 3 (each within the scatter of the next).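

Cyclopentyl, a saturated carbon ring with no hydrogen-bond acceptor, reads the same as dimethylamino (a 1.0-fold lower number from compound 3 to compound 4 (0.01 log units; within the scatter)) and as 3-methyl-1,2-oxazol-5-yl (a 1.0-fold lower number from compound 2 to compound 4 (0.01 log units; within the scatter)), so the three groups cannot be told apart at this position. Only the 1-methyl-1H-pyrazol-4-yl of compound 1 stands apart (a 5.5-fold higher number from compound 1 to compound 4 (0.74 log units; beyond the scatter)). Nothing available explains why that group differs. Still open, on these data alone, is whether a pyrazole without its methyl, or a morpholine ring, would fall with compound 1 or with the other three.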